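Chloro to Bromo on a Protoporphyrinogen Oxidase Inhibitor Core

A few compounds are considered here, and "the series" means these few. Any claim that something is new, unique, unknown or untested is made for them only; others in the source may bear on it.

Compound 1 `CCOC(=O)CCSc1nc2cc(-n3nc(C(C)(C)C)sc3=O)c(Cl)cc2s1` was examined in an assay on isolated protein for inhibition of protoporphyrinogen oxidase (Homo sapiens), read by capillary electrophoresis (on this read-out lower numbers stand for stronger inhibition and higher numbers for weaker inhibition), where compound 1 gives 1280 nM. Its companion compound 2 `C#CCSc1nc2cc(-n3nc(C(C)(C)C)sc3=O)c(Cl)cc2s1` carries ethynyl in place of (ethoxycarbonyl)methyl on a saturated chain carbon bound to a sulfur, and in this assay compound 2 gives 21400 nM. Among the measured compounds shown here, the only measured step is a 17-fold higher number from compound 1 to compound 2 (1.22 log units; beyond the scatter). Compound 1 therefore stands at the lowest of the two numbers, with compound 2 the nearest at a markedly higher number.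

The unmeasured compound 3 `CCOC(=O)CCSc1nc2cc(-n3nc(C(C)(C)C)sc3=O)c(Br)cc2s1` differs from compound 1 in one place: bromo in place of chloro on an aromatic carbon. For the measured compounds named here, no measured step touches this halogen exchange; the single step available, a 17-fold higher number from compound 1 to compound 2 (1.22 log units; beyond the scatter), concerns the chain on the sulfur and says nothing about bromo in place of chloro on the aromatic carbon. With no evidence for a shift, the expected step in this assay is none beyond the scatter. Compound 3 is thus estimated at 1000 nM, within a range of 400 nM to 2500 nM. The expected change is a 1.3-fold lower number from compound 1 to compound 3 (0.11 log units; within the scatter), an estimate rather than a measurement.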

Compound 3, inhibition constant: 27500 nM
The estimate for compound 3 lay 28-fold (1.44 log units) below the measured number; the measured number lies above the stated range.
By their numbers in this assay, from the lowest: compound 1; then compounds 2 and 3 (each within the scatter of the next).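

The exchange of chloro for bromo on this aromatic carbon, ortho to a large group, proves far from neutral in this assay: it gives a 21-fold higher number from compound 1 to compound 3 (1.33 log units; beyond the scatter) and is a large step, even though one halogen atom simply replaces another and the counts of hydrogen-bond donors and acceptors and the net charge stay the same. Among the compounds shown here, until now the only step available lay in the chain on the sulfur, with a 17-fold higher number from compound 1 to compound 2 (1.22 log units; beyond the scatter) as its size, so the new result shows that this halogen position on the shared core can also move the number well beyond the scatter. No measurement shown here bears on the reason for this step.

The compounds shown include only chloro and bromo at this aromatic carbon, so it remains open how fluoro, methyl or a plain hydrogen there would compare with compound 1. On these data alone, it also remains open whether bromo in place of chloro would produce a step of similar size when the sulfur carries a different chain, such as the one ending in ethynyl.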